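A Double Bond Flipped Where Only Limits Stand

A few compounds are considered here, and "the series" means these few. Any claim that something is new, unique, unknown or untested is made for them only; others in the source may bear on it.

Compound 1 `CC(=O)Oc1ccc(/C=C/c2ccc3ccccc3c2)cc1`: > 5000 nM, a limit
Compound 2 `Cc1ccc(/C=C/c2ccc3ccccc3c2)cc1`: > 5000 nM, a limit

In a functional assay on A549 cells (Homo sapiens) for inhibition (on this read-out lower numbers stand for stronger inhibition and higher numbers for weaker inhibition), compound 2 stands at > 5000 nM, which is a limit and not a number. Compound 3 `Cc1ccc(/C=C\c2ccc3ccccc3c2)cc1` has not yet been measured. It is the partner of compound 2: the two compounds have the same atoms and bonds and differ only in configuration as drawn: 1 of 1 stereo elements differ; a double bond is drawn E in compound 2 and Z in compound 3. For the measured compounds named here, the only measured step is a step that the two limits leave unreadable from compound 1 to compound 2, with methyl in place of acetoxy on an aromatic carbon. The picture so far is the limit of > 5000 nM in this assay, at which 2 of the 2 values shown sit. Going by the values given here, no measured step tests a change of double-bond configuration, so no size can be carried over from one. The most likely expectation is that compound 3 also reaches the limit, with some chance of a readable value showing stronger inhibition. The step expected is a step that the limit leaves unreadable from compound 2 to compound 3. For compound 3 the estimated value in this assay is 6000 nM, with an expected range of 1500 nM to 20000 nM.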

Compound 3, half-maximal inhibitory concentration: > 5000 nM
Compound 3: no number, only a limit; the forecaster's own chance of this, stated with the estimate: 60%; the middle value lies beyond the limit too.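

Compound 2 and compound 3 both stand at a limit and not at a number, and the step between them cannot be read. The compounds shown leave open whether drawing the double bond E or Z changes inhibition in this assay at all.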